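The compounds below may be only part of what the source reports. "The series", "measured", "known", "first", "only" and "open" are said of these compounds alone.

In a toxicity assay on HT-29 cells (Homo sapiens) for cytotoxicity (a higher number here means that more compound is tolerated, a lower number that less compound is tolerated), compound 1 (`CN1C(=S)[C@@H](NC(=O)c2nc(Cc3ccccc3)n(C)n2)COc2ccccc21`) reads > 100000 nM as a limit of the assay, not a number. Compound 2 (`CN1C(=S)[C@@H](NC(=O)c2nc(Cc3ccccc3)n(CCC(F)(F)F)n2)COc2ccccc21`) reads > 100000 nM as a limit too. Compound 3 (`CN1C(=S)[C@@H](NC(=O)c2nc(Cc3ccccc3)n(CCCC(F)(F)F)n2)COc2ccccc21`) reads > 100000 nM as a limit too. Within the data shown here, the series so far is the limit of > 100000 nM in this assay, at which 3 of the 3 values shown sit, with no number among them. The steps a step that the two limits leave unreadable from compound 1 to compound 2 and a step that the two limits leave unreadable from compound 1 to compound 3 and a step that the two limits leave unreadable from compound 2 to compound 3 bear on the change, and none gives a size. Compound 4 (`CN1C(=S)[C@@H](NC(=O)c2nc(Cc3ccccc3)n(C3CCCC3)n2)COc2ccccc21`) brings cyclopentyl in place of 4,4,4-trifluorobutyl on an aromatic nitrogen as the next change. For compound 3 the nearest reading is a step that the two limits leave unreadable from compound 2 to compound 3 and it offers no size, so no step beyond the scatter is expected in this assay and no direction can be assigned. The expected step is a number no higher from compound 3 to compound 4 (the limit leaves the size open) on present data. Compound 4 is estimated at 100000 nM with an expected range from 50000 nM to 200000 nM and will most likely be reported as a limit again.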

Compound 4, half-maximal cytotoxic concentration: > 100000 nM
Compound 4 gave a limit, no number (the forecaster's own chance of this, stated with the estimate: 85%); the middle value lies on the limit itself.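

Among these compounds, compound 4 in this assay reads > 100000 nM, a limit of the assay and not a number, so no step to it from compound 1, compound 2 or compound 3 can be read. Whether any group on that aromatic nitrogen changes the read-out stays open, with the whole series at one mark: the limit of > 100000 nM in this assay, at which 4 of the 4 values shown sit.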